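Phenoxy for ethoxyethoxy on the ring nitrogen oxygen

The compounds below may be only part of what the source reports. "The series", "measured", "known", "first", "only" and "open" are said of these compounds alone.

Measured so far:
compound 1 `COC(=O)N1C[C@H](NC(=O)OCCCCC2CCCCC2)C1=O` — 7180 nM
compound 2 `CON1C[C@@H](NC(=O)OCCCCC2CCCCC2)C1=O` — 56 nM
compound 3 `CCOCCON1C(=O)[C@@H](NC(=O)OCCCCC2CCCCC2)[C@@H]1C` — 187 nM

All three numbers come from an assay on HEK293 cells for inhibition of N-acylethanolamine-hydrolyzing acid amidase (Homo sapiens), read by fluorescence, with stated times of 10 min and 50 min; on this read-out lower numbers stand for stronger inhibition and higher numbers for weaker inhibition. Compound 3 stands second highest of the three in this assay: its nearest neighbour is compound 2 with 56 nM, and the gap between them lies beyond the scatter; compound 1 with 7180 nM lies furthest away, again beyond the scatter. So compound 3 sits in the middle of the spread, well below compound 1 and clearly above compound 2.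

Compound 4 `C[C@H]1[C@H](NC(=O)OCCCCC2CCCCC2)C(=O)N1Oc1ccccc1` is still to be measured in this assay. It differs from compound 3 in one place: phenyl in place of 2-ethoxyethyl on an oxygen whose other neighbour is the amide-type nitrogen in the ring. Going by the values given here, no measured pair shows this exchange, so the expectation rests only on compound 3 itself and on the fact that the remaining three compounds differ at the same oxygen by quite different groups and still span a wide range.

Given that spread, the expected step of a 1.2-fold lower number from compound 3 to compound 4 (0.07 log units; within the scatter) is taken as none beyond the scatter, with wide uncertainty in either direction. Compound 4 is expected at 160 nM, within 40 nM to 650 nM.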

Compound 4, half-maximal inhibitory concentration: 23 nM
For compound 4 the middle estimate is 7.0-fold (0.84 log units) above the measured one, outside the stated range (below it).
By their numbers in this assay, from the lowest: compound 4; then compound 2; then compound 3; then compound 1.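

In this assay, going by these compounds alone, the oxygen on the amide-type nitrogen in the ring proves sensitive to the group it carries: 2-ethoxyethyl to phenyl gives an 8.1-fold lower number from compound 3 to compound 4 (0.91 log units; beyond the scatter) and is the first comparison that isolates a change at this place. Compound 4 at 23 nM shows that one six-membered aromatic ring of carbon only is tolerated on this oxygen, and that the ether oxygen of the 2-ethoxyethyl chain, the one hydrogen-bond acceptor leaving in this exchange, is not required for a value at this level. No measurement at hand accounts for the size of this step, which rests on a single pair of compounds.

A cyclohexyl group on this oxygen would help to show whether the lower number follows the aromatic ring or simply the departure of the ether chain. Also open, as far as these compounds go, is whether a phenyl ring bearing an amine or a carboxylic acid, or a pyridine ring in place of phenyl, would keep the number seen for compound 4 at 23 nM in this assay.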